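The source may hold more compounds than are shown below. What is called first, only, known or untested is meant among the compounds shown, and "the series" means these compounds.

Compound 1, `Cc1cc(NC(=O)Nc2ccccc2N)c2ccccc2n1`, gives 300 10^-6 cm/s in an ADME assay for permeability, using PAMPA, at pH 7.4; on this read-out lower numbers stand for lower permeability and higher numbers for higher permeability.
Compound 2, `CSc1ccccc1NC(=O)Nc1cc(C)nc2ccccc12`, gives 1260 10^-6 cm/s in this assay.

Among the two compounds measured so far, compound 1 stands lowest in this assay; its only neighbour is compound 2, which lies a 4.2-fold higher number from compound 1 to compound 2 (0.62 log units; beyond the scatter) away, a change that swaps methylsulfanyl in for amino on an aromatic carbon.

Compound 3, `Cc1cc(NC(=O)Nc2cccnc2)c2ccccc2n1`, has not yet been measured. It differs from compound 1 in one place: pyridin-3-yl in place of 2-aminophenyl on an amide-type nitrogen.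

Within the data shown here, only one measured step bears on this, the one from compound 1 to compound 2, which was a 4.2-fold higher number from compound 1 to compound 2 (0.62 log units; beyond the scatter) when the amino group was replaced. In compound 3 the amino group also leaves, but the whole ring that carried it is exchanged for pyridin-3-yl, so the earlier step is a loose guide rather than a direct match. A small rise is therefore expected for compound 3 in this assay, though one that may stay within the usual scatter of this kind of measurement.

Compound 3 is estimated at 450 10^-6 cm/s, with a likely range from 200 10^-6 cm/s to 1000 10^-6 cm/s, which would mean an expected step of a 1.5-fold higher number from compound 1 to compound 3 (0.18 log units; within the scatter).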

Compound 3, apparent permeability: 63 10^-6 cm/s
Compound 3: middle estimate off by 7.1-fold (0.85 log units), on the high side; measured number outside the range, below it.
By their numbers in this assay, from the lowest: compound 3; then compound 1; then compound 2.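

At this place on the amide-type nitrogen, this assay can move in either direction: swapping the amino group for methylsulfanyl gave a 4.2-fold higher number from compound 1 to compound 2 (0.62 log units; beyond the scatter) and exchanging the whole 2-aminophenyl group for pyridin-3-yl gave a 4.8-fold lower number from compound 1 to compound 3 (0.68 log units; beyond the scatter) in the opposite direction, each step beyond the usual scatter. Both changes take away the amino group, so its loss alone does not set the direction of the step in these compounds; what stands in its place, or whether the carbon-only ring stays, goes with a very different outcome. No measurement among the data shown accounts for the fall seen with compound 3.

The compounds shown leave open whether the fall goes with the ring nitrogen of pyridin-3-yl or with the loss of the amino group from a carbon-only ring, since compound 3 changes both at once. A plain phenyl group on the same amide-type nitrogen would separate these two changes, and pyridin-4-yl would show whether the place of the ring nitrogen matters.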